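This account rests on a few compounds, and the source may have more. Where it says the series, first, only, none or still open, it means among the compounds named here.

Measured in a functional assay on A-375 cells (Homo sapiens) for antiproliferative activity, read by CCK-8 assay, with a stated time of 72 h, tested at 8 uM; a higher number here means a stronger effect of the compound at the concentration tested, a lower number a weaker effect:
- compound 1 `Nc1ccccc1NC(=O)c1ccc(CSC(=S)N2CCN(Cc3ccccn3)CC2)cc1` gives 82.4%
- compound 2 `Nc1ccccc1NC(=O)c1ccc(CSC(=S)N2CCN(c3ccc(Cl)cc3)CC2)cc1` gives 29%
- compound 3 `Nc1ccccc1NC(=O)c1ccc(CSC(=S)N2CCN(c3ccccc3)CC2)cc1` gives 88.6%

Compound 3 stands at the top of these three numbers, though its lead over compound 1 is small: the step of a number 6.2 percentage points higher from compound 1 to compound 3 (within the scatter) lies within the scatter, so the two cannot be ranked against each other. Compound 2 is far behind, as the steps of a number 53.4 percentage points lower from compound 1 to compound 2 (beyond the scatter) and a number 59.6 percentage points higher from compound 2 to compound 3 (beyond the scatter) show.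

Compound 4 `Nc1ccccc1NC(=O)c1ccc(CSC(=S)N2CCN(c3cccnc3)CC2)cc1` differs from compound 3 in one place: pyridin-3-yl in place of phenyl on an amine nitrogen in a ring. For the measured compounds named here, no measured pair tests a ring nitrogen at this position directly. The step from compound 1 to compound 3 shows that two quite different groups on the ring nitrogen, one of them already carrying a pyridine, give numbers within the scatter of each other. The step from compound 2 to compound 3, on the other hand, shows that a single change on the aromatic ring carried by this nitrogen can move the read-out by a large amount. The expected outcome therefore has some uncertainty toward the lower side.

Compound 4 is estimated to give 72%, with a range from 40% to 92%. This estimate means a step of a number 16.6 percentage points lower from compound 3 to compound 4 (beyond the scatter) from compound 3, expected to be modest and downward at most.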

Compound 4, a percentage reported as inhibition, at one concentration (the size of the read-out at that concentration, not a potency): 88.8%
The estimate for compound 4 lay 16.8 percentage points below the measured number; the measured number falls inside the stated range.
By their numbers in this assay, from the lowest: compound 2; then compounds 1, 3 and 4 (each within the scatter of the next).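

In this assay, for the compounds shown here, putting pyridin-3-yl in place of phenyl on the amine nitrogen in a ring adds a ring nitrogen and a hydrogen-bond acceptor to the aromatic ring, yet the step is a number 0.2 percentage points higher from compound 3 to compound 4 (within the scatter), so this change, which no earlier pair tested, leaves the read-out unmoved. Going by these compounds alone, the result also gives a third group on this nitrogen with a high read-out, as the step of a number 6.4 percentage points higher from compound 1 to compound 4 (within the scatter) is likewise within the scatter, while the step of a number 59.8 percentage points higher from compound 2 to compound 4 (beyond the scatter) leaves 4-chlorophenyl as the only one of the four groups that gives a low number. Nothing in the available evidence explains why the ring nitrogen is tolerated here or why the chloro group behaves differently.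

The compounds shown leave open whether the large drop belongs to chloro alone or would recur with fluoro, methyl or methoxy on the same aromatic carbon, and whether pyridin-2-yl or pyridin-4-yl would match pyridin-3-yl. With a single tested concentration, they also leave open how compounds 1, 3 and 4 would compare across a range of concentrations.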